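Amide Nitrogen Substituent Swap in a Limit-Bound Series

The source may report more compounds than this note shows. Statements on the series, on what has been measured and on what is new or still open speak of the compounds shown alone.

Compound 2 `C=CC1=C(C(=O)NC2CCCCC2)C(c2ccc(OC)cc2)OC1` is the reference point. In a functional assay on A549 cells (Homo sapiens) for cytotoxicity, read by MTT assay, with a stated time of 24 h (on this read-out higher numbers stand for weaker inhibition and lower numbers for stronger inhibition), compound 2 gives only a limit, > 100000 nM, and so has no number of its own. Compound 1 `C=CC1=C(C(=O)Nc2ccccc2OC)C(c2ccc(F)cc2)OC1` in this assay likewise stops at a limit, > 100000 nM. Compound 3 `C=CC1=C(C(=O)NCc2ccc(C)cc2)C(c2ccc(F)cc2)OC1` in this assay also sits at a limit, > 100000 nM. Going by the values given here, the one single-point comparison among the measured compounds, a step that the two limits leave unreadable from compound 1 to compound 3, has no readable size. The state of the set is summarised by the limit of > 100000 nM in this assay, at which 3 of the 3 values shown sit.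

Compound 4 `C=CC1=C(C(=O)Nc2ccc(C)cc2)C(c2ccc(OC)cc2)OC1` differs from compound 2 as follows: 4-methylphenyl in place of cyclohexyl on an amide-type nitrogen. Among the compounds with values here, no measured step bears directly on this change; the nearest relative is the unreadable step that the two limits leave unreadable from compound 1 to compound 3, which also exchanges a group on an amide-type nitrogen but leaves no size to carry over. With every measured compound at the limit, the expectation for compound 4 in this assay is that it too most likely returns a limit rather than a number, and the step that the limit leaves unreadable from compound 2 to compound 4 is expected to be none beyond the scatter. For compound 4 the estimate in this assay is 150000 nM, within a range from 40000 nM to 600000 nM.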

Compound 4, half-maximal inhibitory concentration: > 100000 nM
Compound 4 was reported as a limit; the forecaster's own chance of this, stated with the estimate: 85%; the middle value is on the limit's open side.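

Compound 4 gives only a limit in this assay, > 100000 nM. With compound 2 also at a limit, no step can be read between compound 2 and compound 4. The compounds shown leave open whether any amide nitrogen substituent on the shared core gives a measurable value in this assay, as the series stands at: the limit of > 100000 nM in this assay, at which 4 of the 4 values shown sit.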